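A few compounds are considered here, and "the series" means these few. Any claim that something is new, unique, unknown or untested is made for them only; others in the source may bear on it.

Of the compounds shown here, three have been measured in an assay on a protein complex for inhibition of ubiquitin carboxyl-terminal hydrolase 1/WD repeat-containing protein 48 (Homo sapiens), read by fluorescence; on this read-out higher numbers stand for weaker inhibition and lower numbers for stronger inhibition. Compound 1 `CC(C)c1ccccc1-c1nccc(NCc2ccc(-c3cccnc3)cc2)n1` gives 150 nM. Compound 2 `Cc1cc(NCc2ccc(-c3cccnc3)cc2)nc(-c2ccccc2C(C)C)n1` gives 210 nM. Compound 3 `Cc1cnc(-c2ccccc2C(C)C)nc1NCC1CCN(c2cccnc2)CC1` gives 80 nM. The difference between the core of compound 1 and the core of compound 3 is not broken down here; their values lie within the scatter of each other, while the gap between compound 3 and compound 2 lies beyond it.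

From compound 1 to compound 2 the change is methyl in place of hydrogen on an aromatic carbon, and it made a 1.4-fold higher number from compound 1 to compound 2 (0.15 log units; within the scatter). Compound 4 `Cc1ccc(N2CCC(CNc3nc(-c4ccccc4C(C)C)ncc3C)CC2)cn1` is the not yet measured partner of compound 3, and the change is methyl in place of hydrogen on an aromatic carbon. It is the same kind of change, but not the same: in compound 2 the methyl sits on a ring with 2 nitrogen, meta to a 2-isopropylphenyl group and opposite the ring nitrogen, whereas in compound 4 it sits on a ring with 1 nitrogen, para to a large group.

In this assay compound 4 is expected to give 100 nM, between 50 nM and 220 nM. That expectation means a step of a 1.3-fold higher number from compound 3 to compound 4 (0.10 log units; within the scatter) and rests on compound 1 to compound 2 having moved only a 1.4-fold higher number from compound 1 to compound 2 (0.15 log units; within the scatter).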

Compound 4, half-maximal inhibitory concentration: 90 nM
The estimate for compound 4 lay 1.1-fold (0.05 log units) above the measured number; the measured number falls inside the stated range.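

In this assay, replacing pyridin-3-yl with 6-methylpyridin-3-yl made a 1.1-fold higher number from compound 3 to compound 4 (0.05 log units; within the scatter). Set beside the earlier case, the methyl change behaved alike on the two cores, with no difference that can be told from the scatter: the same change on two cores in this assay, a 1.4-fold higher number (0.15 log units; within the scatter) from compound 1 to compound 2 and a 1.1-fold higher number (0.05 log units; within the scatter) from compound 3 to compound 4, 1.2-fold (0.09 log units) apart, within the scatter of two such steps. This shows that, in these two pairs, a methyl in place of hydrogen on an aromatic carbon left the number within the scatter, but it does not establish a rule for the series, since the two methyl groups sit on different rings, one with 2 nitrogen and one with 1 nitrogen, and neither step can be read as a real gain or loss.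

The compounds shown leave open whether a different group at the place next to the ring nitrogen, such as methoxy, trifluoromethyl or an amine, would move the number beyond the scatter. They also leave open whether a methyl elsewhere on that ring, or the same change on a further core, would stay as quiet.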